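The source may hold more compounds than are shown below. What is called first, only, known or untested is meant among the compounds shown, and "the series" means these compounds.

Measured compounds:
Compound 1 `CC(C)COc1ccc(-c2c(C#N)c(N)nc(SCC(N)=O)c2C#N)cc1` gives 9% in an assay on CHO cells for displacement of a labelled ligand from adenosine receptor A3 (Homo sapiens), read by scintillation counting, with a stated time of 120 min, tested at 1 uM; a higher number here means more inhibition at the concentration tested (going by the name of the read-out), a lower number less inhibition.
Compound 2 `N#Cc1c(N)nc(SCC(=O)NCO)c(C#N)c1-c1ccc(OCC2CC2)cc1` gives 8% in this assay.
Compound 3 `N#Cc1c(N)nc(SCc2cccnc2)c(C#N)c1-c1ccc(OCC2CC2)cc1` gives 19% in this assay.

Compound 1 gives the middle value of the three, and its gaps to compound 2 and to compound 3 both fall within the scatter, so no ordering among them can be read. Compound 4 `CCOc1ccc(-c2c(C#N)c(N)nc(SCC(N)=O)c2C#N)cc1` differs from compound 1 by methyl in place of isopropyl on a saturated chain carbon bound to an oxygen on an aromatic ring, which at the chain level reads isobutoxy to ethoxy. Among the measured compounds shown here, the only measured step, a number 11 percentage points higher from compound 2 to compound 3 (beyond the scatter), changes the group on the saturated chain carbon bound to a sulfur and leaves the oxygen chain untouched, so it does not bear on this change. With nothing to point either way, the step is expected to stay within the scatter: no change at the digits printed from compound 1 to compound 4 (within the scatter). Compound 4 is therefore estimated at 9%, in the range 0% to 22%.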

Compound 4, a percentage reported as inhibition, at one concentration (the size of the read-out at that concentration, not a potency): 20%
Compound 4: the middle estimate sits 11 percentage points below what was measured; measured number inside the range.
By their numbers in this assay, from the lowest: compounds 2, 1, 3 and 4 (each within the scatter of the next, the first and the last beyond it).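

In this assay, the size of the chain on the oxygen turns out to matter: going from isobutoxy to ethoxy gives a number 11 percentage points higher from compound 1 to compound 4 (beyond the scatter) with the rest of the molecule unchanged. Among the compounds shown here, this is the first sign that this position can shift the number, since the earlier step changed only the group on the sulfur side. Nothing shown accounts for the shift.

Open, going by these compounds, is what methoxy or a longer chain such as butoxy would give here. Also open, on these data alone, is whether ethoxy would have the same effect alongside the pyridin-3-yl group.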